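The source may hold more compounds than are shown below. What is called first, only, known or untested is meant among the compounds shown, and "the series" means these compounds.

Measured compounds in an ADME assay on microsomes from liver (Homo sapiens) for metabolic stability, tested at 2.5 uM; on this read-out lower numbers stand for slow clearance and higher numbers for fast clearance:

- compound 1, `Cc1ccc(S(=O)(=O)c2cnc3c(F)cccc3c2-c2ccc(F)cc2)cc1F`, gives 2.75 mL/min
- compound 2, `O=S(=O)(c1ccc(F)c(F)c1)c1cnc2c(F)cccc2c1-c1ccc(F)cc1`, gives 0.78 mL/min
- compound 3, `Cc1ccc(S(=O)(=O)c2cnc3cc(F)ccc3c2-c2cccc(F)c2)cc1F`, gives 0.41 mL/min

Compounds 1 and 2 share one core; compound 3 sits on a second core, and the difference between the two cores is not broken down here. Compound 3 has the lowest number of the three, but its gap to compound 2 stays within the scatter, so no order between those two is claimed; its gap to compound 1 is beyond the scatter.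

Within the first core, the change from compound 1 to compound 2 is fluoro in place of methyl on an aromatic carbon. This gives a 3.5-fold lower number from compound 1 to compound 2 (0.55 log units; beyond the scatter).

The unmeasured compound 4, `O=S(=O)(c1ccc(F)c(F)c1)c1cnc2cc(F)ccc2c1-c1cccc(F)c1`, carries the same change on the second core: fluoro in place of methyl on an aromatic carbon. The surroundings of the change read the same in both pairs, so this is the same change applied to a different core. Whether the second core carries it the same way is not shown by any other pair here, so the one measured step is the only guide.

On that basis the step from compound 3 to compound 4 is expected to be in the same direction as the step from compound 1 to compound 2, tempered because the starting number of compound 3 at 0.41 mL/min is already low: a 2.3-fold lower number from compound 3 to compound 4 (0.36 log units; beyond the scatter). For compound 4 in this assay the estimate is 0.18 mL/min, with a range of 0.07 mL/min to 0.5 mL/min.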

Compound 4, intrinsic clearance in a liver preparation (reported as CLH), per the amount of preparation that the assay uses: 0.6 mL/min
For compound 4 the middle estimate is 3.3-fold (0.52 log units) below the measured one; measured number outside the range, above it.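

In this assay, the swap of 3-fluoro-4-methylphenyl to 3,4-difluorophenyl on the second core gives a 1.5-fold higher number from compound 3 to compound 4 (0.17 log units; within the scatter), so no order between these two compounds is claimed. The same swap therefore does not carry a fixed step from one core to the other in this series, and the step on the first core is not a reliable guide to the step on the second: the same change on two cores in this assay, a 3.5-fold lower number (0.55 log units; beyond the scatter) from compound 1 to compound 2 and a 1.5-fold higher number (0.17 log units; within the scatter) from compound 3 to compound 4, 5.2-fold (0.71 log units) apart, beyond the scatter of two such steps

This comparison rests on a single pair per core, so it shows that the outcome of the swap depends on the core in this one case, but it does not show which feature of the cores is responsible, nor whether a third core would follow either pair.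

The compounds shown leave open how this place responds to groups other than methyl and fluoro, such as chloro, methoxy or nitrile, and whether those groups would also read differently on the two cores. Also open, going by these compounds, is whether a further matched pair on either core would confirm the step seen there, which would show how firmly each single step can be taken.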